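The compounds below may be only part of what the source reports. "The series", "measured", "known", "first", "only" and "open" are said of these compounds alone.

Compound 3, with the structure `O=C(O)Cc1sc(C(c2ccc(F)cc2)c2ccc(F)cc2)nc1-c1ccoc1`, is the starting point of this step. In an in vitro functional assay on HEK285-7 cells for antagonist activity at prostaglandin D2 receptor 2 (Homo sapiens), read by BRET and beta-arrestin recruitment (a lower number here means a stronger inhibitor, a higher number a weaker inhibitor), compound 3 gives 130 nM, the lowest of the two numbers that were obtained among the compounds that share the same core. Compound 1, `Cc1nc(-c2ccc(Cl)cc2)c(CC(=O)O)s1`, is the nearest of these: in this assay compound 1 gives 41000 nM, a gap to compound 3 that lies well beyond the scatter of repeated measurements. Compound 2, `CCC(c1ccccc1)c1nc(-c2ccc(Cl)cc2)c(CC(=O)O)s1`, did not give a number at all: in this assay compound 2 is reported only at the limit > 100000 nM, the boundary of what the assay can read, as noted in the limit of > 100000 nM in this assay, at which 1 of the 3 values shown sits.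

Compound 4, `O=C(O)Cc1sc(C(c2ccc(F)cc2)c2ccc(F)cc2)nc1-c1ccnc(N2CCC2)c1`, has not yet been measured. It differs from compound 3 in one place: 2-(azetidin-1-yl)pyridin-4-yl in place of furan-3-yl on an aromatic carbon. Within the data shown here, no two measured compounds differ in just this way, so the size of the step has to be judged from the change itself. The account here expects compound 4 to remain close to compound 3, with a step of a 1.4-fold lower number from compound 3 to compound 4 (0.16 log units; within the scatter) that may not exceed the usual scatter in either direction. The estimate for compound 4 in this assay is 90 nM, with a range from 15 nM to 500 nM.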

Compound 4, half-maximal inhibitory concentration: > 100000 nM
Compound 4 was reported as a limit; the forecaster's own chance of this, stated with the estimate: 3%; at least 1100-fold (3.04 log units) between middle value and limit.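

At the aromatic carbon next to the ring nitrogen and next to the ring atom that bears a carboxymethyl group, the group is far from interchangeable: with the rest of compound 3 held constant, 2-(azetidin-1-yl)pyridin-4-yl in place of furan-3-yl gives an at least 760-fold higher number from compound 3 to compound 4 (2.88 log units; beyond the scatter) in this assay. Among these compounds, no earlier pair isolated a change at this position, so this step is the first direct reading of how much the series can lose here. Compound 4 is reported only as the limit > 100000 nM, so the real size of the step cannot be read beyond that limit: the limit of > 100000 nM in this assay, at which 2 of the 4 values shown sit.

The compounds shown leave open whether the loss follows the pyridin-4-yl ring itself or the azetidin-1-yl group on it, since both enter together in this single change. A plain pyridin-4-yl group, a phenyl group, or a smaller amine such as dimethylamino in place of the azetidin-1-yl group would separate these two parts and show how much of this position can still be changed.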